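Difluoromethoxy for ethoxy on an aryl ether

This account rests on a few compounds, and the source may have more. Where it says the series, first, only, none or still open, it means among the compounds named here.

The measured compounds:
compound 1 `CCc1nc(NC(CC)CC)c(OC)nc1-c1ccc(OC(F)F)cc1Cl`: 1.4 nM
compound 2 `CCc1nc(-c2ccc(OC)cc2O)c(CC)nc1NC(CC)CC`: 1180 nM
compound 3 `CCOc1ccc(-c2nc(OC)c(NC(CC)CC)nc2C)c(Cl)c1`: 5.9 nM

In an assay on IMR-32 cells for displacement of a labelled ligand from corticotropin-releasing factor receptor 1 (Homo sapiens), read by scintillation counting, with a stated time of 2 h (on this read-out lower numbers stand for stronger inhibition and higher numbers for weaker inhibition), compound 3 gives 5.9 nM, the second highest of the three numbers. Its nearest neighbour is compound 1, which in this assay gives 1.4 nM, a lower number beyond the scatter. Compound 2 stands furthest away with 1180 nM, a much higher number.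

Compound 4 `CCC(CC)Nc1nc(C)c(-c2ccc(OC(F)F)cc2Cl)nc1OC` has not been measured. It differs from compound 3 in one place: difluoromethyl in place of ethyl on an oxygen on an aromatic ring. Within the data shown here, no step between two measured compounds isolates this change. Compound 1 also carries a difluoromethoxy on its aryl ring, yet it differs from compound 3 elsewhere as well, so its lower number can only hint at the direction.

The expectation is therefore modest: a step that is small, at most a little toward a lower number, and possibly none beyond the scatter, giving a 1.7-fold lower number from compound 3 to compound 4 (0.23 log units; within the scatter) from compound 3 to compound 4. Compound 4 is estimated at 3.5 nM in this assay, with a range from 1.2 nM to 10 nM.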

Compound 4, inhibition constant: 4.6 nM
The estimate for compound 4 lay 1.3-fold (0.12 log units) below the measured number; low and high end bracket the measured number.
By their numbers in this assay, from the lowest: compound 1; then compounds 4 and 3 (each within the scatter of the next); then compound 2.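

In this assay, the exchange of ethyl for difluoromethyl on an oxygen on an aromatic ring is now isolated in a single step, a 1.3-fold lower number from compound 3 to compound 4 (0.11 log units; within the scatter), which shows that this change alone makes no difference beyond the scatter in this core. With the difluoromethoxy group held constant, the second step, hydrogen in place of methyl on a saturated chain carbon bound to an aromatic carbon, is a 3.3-fold higher number from compound 1 to compound 4 (0.52 log units; beyond the scatter), a modest change beyond the scatter that shows this chain carbon also bears on the read-out. No measured evidence accounts for either step.

The compounds shown leave open whether other groups on the same oxygen, such as trifluoromethyl, methyl or a longer chain, would also stay within the scatter of compound 3. They also leave open whether the exchange of ethoxy for difluoromethoxy would give a similarly small step in a compound carrying the extra methyl of compound 1, and compound 2 differs in too many places to help with either question.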